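Swapping a methoxy for a chloro on the aryl ring

The compounds below may be only part of what the source reports. "The series", "measured", "known", "first", "only" and "open" are said of these compounds alone.

Three compounds of a shared core, each carrying an aryl group and a ring-bearing amine, have been tested in a functional assay on CHO cells for antagonist activity at adenosine receptor A2b (Homo sapiens), read by 33P incorporation, with a stated time of 20 min; a lower number here means a stronger inhibitor, a higher number a weaker inhibitor. Compound 1 `COc1ccc(-c2nc3c(NC4CCCC4)ncnc3n2C)cc1` gives only a limit in this assay, > 30000 nM, so no exact number exists for it. Compound 2 `CCCn1c(-c2ccccc2)nc2c(NC3CCCC3)ncnc21`, with a propyl on the ring nitrogen and an unsubstituted phenyl, gives 3430 nM in this assay. Compound 3 `Cn1c(-c2ccccc2)nc2c(NC3CCOC3)ncnc21`, with an oxolane amine, gives 13300 nM in this assay. Compound 1 therefore sits at the weak end of what has been measured, beyond the limit where (the limit of > 30000 nM in this assay, at which 1 of the 3 values shown sits).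

Compound 4 `Cn1c(-c2ccc(Cl)cc2)nc2c(NC3CCCC3)ncnc21` has not yet been tested. It differs from compound 1 in one place: chloro in place of methoxy on an aromatic carbon, para to a large group. Among the compounds with values here, no measured pair shows this change. Since compound 1 is only a limit, the step from compound 1 to compound 4 in this assay is expected as an at least 2.5-fold lower number from compound 1 to compound 4 (0.39 log units; beyond the scatter), toward stronger inhibition, but with wide uncertainty. For compound 4 a value of about 12000 nM in this assay is estimated, within 2500 nM to 40000 nM.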

Compound 4, inhibition constant: > 30000 nM
Compound 4 was reported as a limit (the forecaster's own chance of this, stated with the estimate: 35%); at least 2.5-fold (0.39 log units) between middle value and limit.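

Compound 1 and compound 4 both give only a limit, not an exact number, so the step between them cannot be read: the limit of > 30000 nM in this assay, at which 2 of the 4 values shown sit.

The compounds shown leave open whether methoxy or chloro on the aryl ring gives the stronger inhibitor in this assay.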